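Swapping Ethoxycarbonyl for Acetyl at the Assay Limit

The source may hold more compounds than are shown below. What is called first, only, known or untested is meant among the compounds shown, and "the series" means these compounds.

In a functional assay on RPMI-8226 cells (Homo sapiens) for cytotoxicity, read by fluorescence, with a stated time of 72 h (on this read-out lower numbers stand for stronger inhibition and higher numbers for weaker inhibition), compound 2 (`CCOC(=O)n1nc(N)c(/N=N/c2ccc(O)cc2)c1N`) gives > 100000 nM and that entry is a limit, not a number. Compound 3 (`Nc1n[nH]c(N)c1/N=N/c1cc[n+]([O-])cc1`) gives > 100000 nM and that entry is a limit too. Compound 2 therefore stands at the limit of > 100000 nM in this assay, at which 2 of the 3 values shown sit, and has no exact value. Compound 1 (`Nc1n[nH]c(N)c1/N=N/c1ccncc1`) gives a true number of 6200 nM in the same test. Compound 4 (`CC(=O)n1nc(N)c(/N=N/c2ccc(O)cc2)c1N`) changes one group of compound 2: ethoxycarbonyl to acetyl, which is methyl in place of ethoxy on a carbonyl carbon. Going by the values given here, no measured pair shows this change, so in this assay only a small step toward stronger inhibition is expected. The expected move is an at least 1.4-fold lower number from compound 2 to compound 4 (0.15 log units; that floor lies within the scatter) and it may not be resolved at all. Compound 4 is estimated at 70000 nM with an expected range of 20000 nM to 100000 nM and could again turn out to be only a limit.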

Compound 4, half-maximal inhibitory concentration: > 100000 nM
Compound 4: no number, only a limit; the forecaster's own chance of this, stated with the estimate: 60%; middle value at least 1.4-fold (0.15 log units) from the limit.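

Going by these compounds alone, compound 2 and compound 4 both give only a limit in this assay, not a number, so no step between them can be read. On these data alone, whether swapping ethoxycarbonyl for acetyl changes inhibition at all remains open.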